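From Methyl to Chloro at the Limit of the Assay

The compounds below may be only part of what the source reports. "The series", "measured", "known", "first", "only" and "open" are said of these compounds alone.

Compound 3 (`Cc1ccccc1NNC(=O)c1ccccc1NS(=O)(=O)c1cnc(O)nc1O`) gives > 20000 nM in a functional assay on A549 cells (Homo sapiens) for antiproliferative activity, read by MTT assay, with a stated time of 24 h (a lower number here means a stronger inhibitor, a higher number a weaker inhibitor), as a limit of the assay and not a number. Compound 3 thus stands at the limit of > 20000 nM in this assay, at which 1 of the 3 values shown sits, and offers no exact starting point.

Two related compounds do carry numbers. In this assay compound 1 (`Cc1ccccc1NNC(=O)c1ccc(NS(=O)(=O)c2cnc(O)nc2O)cc1`) gives 14500 nM and compound 2 (`O=C(NNc1ccccc1F)c1ccc(NS(=O)(=O)c2cnc(O)nc2O)cc1`) gives 11700 nM on the same read-out.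

Compound 4 (`O=C(NNc1ccccc1Cl)c1ccccc1NS(=O)(=O)c1cnc(O)nc1O`) differs from compound 3 by one exchange, chloro in place of methyl on an aromatic carbon, ortho to a large group (chloro in place of methyl on an aromatic carbon). In other words, 2-methylphenyl becomes 2-chlorophenyl.

Going by the values given here, no measured step has chloro entering. The nearest one has fluoro replacing methyl on an aromatic carbon, and it amounts to a 1.2-fold lower number from compound 1 to compound 2 (0.09 log units; within the scatter) in a different parent structure. With that single step as the guide, no change beyond the scatter is expected in this assay for compound 4 relative to compound 3.

The expected step, an estimate taken from a limit, reads an at least 1.1-fold lower number from compound 3 to compound 4 (0.04 log units; that floor lies within the scatter) and should be treated with caution. The estimated value for compound 4 is 18000 nM with an expected range from 9000 nM to 32000 nM and a fair chance of only a limit.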

Compound 4, half-maximal inhibitory concentration: 5480 nM
For compound 4 the middle estimate is 3.3-fold (0.52 log units) above the measured one; the whole stated range lies above it.
By their numbers in this assay, from the lowest: compound 4; then compounds 2 and 1 (each within the scatter of the next). At a limit, above all of these: compound 3.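

In this assay, the exchange of 2-methylphenyl for 2-chlorophenyl, on an aromatic carbon ortho to a large group, gives an at least 3.6-fold lower number from compound 3 to compound 4 (0.56 log units; beyond the scatter). Going by these compounds alone, the only earlier exchange at this aromatic carbon, in a different parent, gave a 1.2-fold lower number from compound 1 to compound 2 (0.09 log units; within the scatter), so the new step is the first in this set to show that a change at this position can move the number beyond the scatter, and it also brings a measured value to a parent that previously had only a limit. The limit for compound 3 is not a number, which makes the new step a floor rather than a measured size: the limit of > 20000 nM in this assay, at which 1 of the 4 values shown sits.

The compounds shown leave open whether chloro would give a similar step in the parent of compound 1, and whether fluoro would do so in the parent of compound 3, so the effect of the entering group cannot yet be separated from that of the parent. Going by these compounds, how a methoxy group, an amine or a longer chain on the same aromatic carbon would read also remains open.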